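The source may report more compounds than this note shows. Statements on the series, on what has been measured and on what is new or still open speak of the compounds shown alone.

The measured compounds:

compound 1, `CC/C=C\C[C@H]1C(=O)C=C[C@H]1CC(=O)OCC` — 146 uM in an ADME assay on RAW264.7 cells (Mus musculus) for cytotoxicity, read by MTT assay, with a stated time of 24 h; a higher number here means that more compound is tolerated, a lower number that less compound is tolerated
compound 2, `CC/C=C\C[C@H]1C(=O)C=C[C@H]1CC(=O)OCCOCCOC` — 161 uM in this assay

Compound 1 holds the lowest of the two numbers in this assay. Its nearest neighbour is compound 2, reached by the step of a 1.1-fold higher number from compound 1 to compound 2 (0.04 log units; within the scatter), which lies within the scatter, so the two compounds cannot be told apart on these numbers.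

Compound 3, `CC/C=C\C[C@H]1C(=O)C=C[C@H]1CC(=O)OC(C)C`, differs from compound 1 by methyl in place of hydrogen on a saturated chain carbon bound to an oxygen next to a carbonyl group and a saturated chain carbon. Among the measured compounds shown here, only one measured step exists, the one from compound 1 to compound 2, and it changes the molecule at a different place from the change that leads to compound 3, so no measured step bears directly on it. What that step does show is that altering the ester end of compound 1 left this assay essentially unchanged, with a 1.1-fold higher number from compound 1 to compound 2 (0.04 log units; within the scatter). On that basis the expected step is a 1.0-fold higher number from compound 1 to compound 3 (0.01 log units; within the scatter), no movement beyond the scatter in either direction. Compound 3 is therefore estimated at 150 uM, with a range from 85 uM to 260 uM.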

Compound 3, half-maximal toxic concentration: 58 uM
Estimate against measurement, compound 3: 2.6-fold (0.41 log units) above; measured number below the stated range.
By their numbers in this assay, from the lowest: compound 3; then compounds 1 and 2 (each within the scatter of the next).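

The ester end of the molecule is not indifferent in this assay: methyl in place of hydrogen on a saturated chain carbon bound to an oxygen next to a carbonyl group, which turns ethoxycarbonyl into isopropoxycarbonyl, gives a 2.5-fold lower number from compound 1 to compound 3 (0.40 log units; beyond the scatter), a modest step but the first in this series beyond the scatter. Isopropyl in place of 2-(2-methoxyethoxy)ethyl on that oxygen gives a 2.8-fold lower number from compound 2 to compound 3 (0.44 log units; beyond the scatter), so compound 3 stands apart from both earlier compounds, whereas the much larger change at this end of the molecule gave only a 1.1-fold higher number from compound 1 to compound 2 (0.04 log units; within the scatter), within the scatter, and the size of the added group alone therefore does not order these three compounds. Nothing measured on these compounds accounts for the lower number of compound 3.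

The compounds shown leave open whether the lower number holds for other groups on this oxygen, such as tert-butyl, cyclopentyl or unbranched propyl. They also leave open where a carboxylic acid or an amide at this end of the molecule would fall in this assay.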